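Thiosemicarbazone Aryl Substituent Swap and Expected Growth Inhibition

The source may hold more compounds than are shown below. What is called first, only, known or untested is meant among the compounds shown, and "the series" means these compounds.

Compound 1 `COc1ccc(/C=N\NC(=S)NC(C)(C)CCC[C@](C)(O)[C@@H]2CC=C(C)CC2)cc1`: 7660 nM in a functional assay on PCO3 cells (Homo sapiens) for cytotoxicity, read by sulforhodamine B assay; a lower number here means a stronger inhibitor of growth, a higher number a weaker inhibitor of growth
Compound 2 `CC1=CC[C@@H]([C@@](C)(O)CCCC(C)(C)NC(=S)N/N=C\c2ccc(O)cc2)CC1`: 6230 nM in this assay

Compound 2 and compound 1 lie within the scatter of each other in this assay, the step being a 1.2-fold lower number from compound 1 to compound 2 (0.09 log units; within the scatter). Compound 3 `CC1=CC[C@@H]([C@@](C)(O)CCCC(C)(C)NC(=S)N/N=C\c2ccc(N(C)C)cc2)CC1` differs from compound 2 by dimethylamino in place of hydroxy on an aromatic carbon. Within the data shown here, the only measured step, a 1.2-fold lower number from compound 1 to compound 2 (0.09 log units; within the scatter), concerns a different change at the same position and was within the scatter, so no firm guide exists for this swap. Compound 3 is therefore expected near 5000 nM, in a range of 1800 nM to 14000 nM. The expected step is a 1.2-fold lower number from compound 2 to compound 3 (0.10 log units; within the scatter).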

Compound 3, concentration for 50% growth inhibition: 13700 nM
Compound 3: middle estimate off by 2.7-fold (0.44 log units), on the low side; the measured number falls inside the stated range.
By their numbers in this assay, from the lowest: compounds 2, 1 and 3 (each within the scatter of the next, the first and the last beyond it).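

In this assay, among these compounds, the swap from hydroxy to dimethylamino on this aromatic carbon gives the first step at this position beyond the scatter (a 2.2-fold higher number from compound 2 to compound 3 (0.34 log units; beyond the scatter)), a modest move toward weaker growth inhibition. Against the methoxy group of compound 1, dimethylamino stays within the scatter (a 1.8-fold higher number from compound 1 to compound 3 (0.25 log units; within the scatter)), so the hydroxy and dimethylamino compounds alone are separated. No evidence available here bears on this result. Going by these compounds, whether a primary amine, a carboxylic acid or a fluorine at this position would move the number further remains open.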